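Swapping the methylsulfonyl for a fluoro-methyl aryl

The source may hold more compounds than are shown below. What is called first, only, known or untested is meant among the compounds shown, and "the series" means these compounds.

Compound 2 `Cn1ccnc1[C@@H](CC(=O)O)c1ccc(OCc2cccc(-c3ccccc3S(C)(=O)=O)c2)cc1` carries the highest number of the two measured in an assay on CHO cells for agonist activity at Free fatty acid receptor 1 (Homo sapiens), read by luminescence, with a stated time of 20 s, in the presence of a further agent that is not named here (a lower number here means that less compound is needed, a higher number that more compound is needed for the effect), giving 23000 nM. For the measured compounds named here, its nearest neighbour is compound 1 `CCc1ccccc1-c1cccc(COc2ccc([C@H](CC(=O)O)c3nccn3C)cc2)c1`, which in this assay gives 48 nM; the single recorded step, a 480-fold higher number from compound 1 to compound 2 (2.68 log units; beyond the scatter), arises from the change of ethyl to methylsulfonyl on an aromatic carbon. Compound 3 `Cc1cc(F)ccc1-c1cccc(COc2ccc([C@H](CC(=O)O)c3nccn3C)cc2)c1` has not been measured. It differs from compound 2 by 4-fluoro-2-methylphenyl in place of 2-(methylsulfonyl)phenyl on an aromatic carbon. Going by the values given here, the only step that bears on this change is the one from compound 1 to compound 2, which was large and went toward a higher number when the ethyl was replaced by methylsulfonyl. The new group in compound 3 returns to a carbon-only substituent with a methyl and a fluorine on the ring, and so the reverse of that step is the relevant guide. On that basis compound 3 is expected to show a large step toward a lower number, a 380-fold lower number from compound 2 to compound 3 (2.58 log units; beyond the scatter), because compound 1 with its ethyl gave 48 nM. The estimate for compound 3 in this assay is therefore 60 nM, with a range from 15 nM to 250 nM.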

Compound 3, half-maximal effective concentration: 59 nM
For compound 3 the middle estimate is 1.0-fold (0.01 log units) above the measured one; the range from low to high includes it.
By their numbers in this assay, from the lowest: compounds 1 and 3 (each within the scatter of the next); then compound 2.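

In this assay, the change from 2-(methylsulfonyl)phenyl to 4-fluoro-2-methylphenyl, on an aromatic carbon meta to a large group, gives a 390-fold lower number from compound 2 to compound 3 (2.59 log units; beyond the scatter), so a second replacement of the methylsulfonyl-bearing group now accompanies a large step toward a lower number. The comparison with the ethyl-bearing group gives a 1.2-fold higher number from compound 1 to compound 3 (0.09 log units; within the scatter), which means that 2-ethylphenyl and 4-fluoro-2-methylphenyl cannot be told apart in this assay, and among these three groups only 2-(methylsulfonyl)phenyl stands apart. Nothing available accounts for the gap between the methylsulfonyl-bearing group and the other two groups.

As far as these compounds go, it remains open whether the high number of compound 2 is specific to methylsulfonyl or would also appear with a methoxy group, a nitrile or an amine on that aromatic ring. Also open, from the compounds shown here alone, is what the fluorine and the methyl of compound 3 each contribute, and whether a plain phenyl at this place would stay with compound 1 and compound 3 or move toward compound 2.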